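Adding a methoxy group to compound 1

This account rests on a few compounds, and the source may have more. Where it says the series, first, only, none or still open, it means among the compounds named here.

Compound 1, `O=C(Cc1ccccc1)NS(=O)(=O)C(F)(F)F`: 6.2 mg/kg
Compound 2, `O=C(Cc1ccc([N+](=O)[O-])cc1)NS(=O)(=O)C(F)(F)F`: 12 mg/kg
Compound 3, `COc1cccc(CC(=O)NS(=O)(=O)C(F)(F)F)c1`: not yet measured

Among the measured compounds shown here, in a functional assay on the whole organism with Mus musculus as the target, in the maximal electroshock model (on this read-out lower numbers stand for an effect already at smaller amounts and higher numbers for an effect only at larger amounts of compound), only two compounds have numbers so far. Compound 1 gives 6.2 mg/kg and compound 2 gives 12 mg/kg. These two values lie within the scatter of each other, so compound 1 cannot be ranked ahead of compound 2 on this evidence.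

Compound 3 keeps the core of compound 1 and differs from it as follows: methoxy in place of hydrogen on an aromatic carbon. For the measured compounds named here, the only measured step that bears on this change is a 1.9-fold higher number from compound 1 to compound 2 (0.29 log units; within the scatter), with nitro in place of hydrogen on an aromatic carbon. Going by the values given here, that is a single step with a different group, and no compound carrying methoxy has been measured, so it offers only loose guidance. On this evidence, no step beyond the scatter is expected in this assay, and no firm direction can be given.

The expected change is a 1.4-fold higher number from compound 1 to compound 3 (0.14 log units; within the scatter). For compound 3 the estimated value is 8.5 mg/kg, with an expected range from 3.5 mg/kg to 21 mg/kg.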

Compound 3, dose for half-maximal effect: 19 mg/kg
Beside the measured number, compound 3's estimate is 2.2-fold (0.35 log units) below it; measured number inside the range.
By their numbers in this assay, from the lowest: compounds 1, 2 and 3 (each within the scatter of the next, the first and the last beyond it).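

In this assay, among the compounds shown here, methoxy in place of hydrogen, on an aromatic carbon meta to a large group, gives the first step to lie beyond the scatter: a 3.1-fold higher number from compound 1 to compound 3 (0.49 log units; beyond the scatter). The earlier nitro change, a 1.9-fold higher number from compound 1 to compound 2 (0.29 log units; within the scatter), did not settle whether putting a group on this aromatic ring could shift the number at all, whereas this modest step shows that at least one such replacement does, and that it moves toward an effect only at larger amounts of compound. Nothing available explains why this replacement has this effect on the result.

The compounds shown carry methoxy at this one place only, so they leave open whether the step belongs to the group itself or to where it sits on the ring. They also leave open whether a hydroxyl group, a fluorine atom or a longer chain such as ethoxy at the same place would give a number closer to that of compound 1 or move further from it.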